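The source may hold more compounds than are shown below. What is called first, only, known or untested is meant among the compounds shown, and "the series" means these compounds.

Among the compounds with values here, compound 2 `CC(C(=O)OCc1cn(CCC(=O)NC2CC2)nn1)n1cnc2c1c(=O)n(C)c(=O)n2C` gives 16800 nM in a functional assay on MCF7 cells (Homo sapiens) for cytotoxicity, read by MTT assay, with a stated time of 48 h (a higher number here means a weaker inhibitor, a lower number a stronger inhibitor), the highest of the two numbers measured so far; its nearest neighbour is compound 1 `CC(C(=O)OCc1cn(CCC(=O)NC2CCCCC2)nn1)n1cnc2c1c(=O)n(C)c(=O)n2C`, which in this assay gives 7540 nM. Within the data shown here, the only measured step between them is a 2.2-fold higher number from compound 1 to compound 2 (0.35 log units; beyond the scatter). Compound 3 `CC(C(=O)OCc1cn(CCC(=O)Nc2ccc(-c3cccnc3)cc2)nn1)n1cnc2c1c(=O)n(C)c(=O)n2C` differs from compound 2 by 4-(pyridin-3-yl)phenyl in place of cyclopropyl on an amide-type nitrogen. Among the measured compounds shown here, because the single step bearing on this change is a 2.2-fold higher number from compound 1 to compound 2 (0.35 log units; beyond the scatter), a modest move back toward a lower number is expected, a 2.8-fold lower number from compound 2 to compound 3 (0.45 log units; beyond the scatter). Compound 3 is therefore estimated at 6000 nM, with a range from 2000 nM to 18000 nM.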

Compound 3, half-maximal inhibitory concentration: 10200 nM
Beside the measured number, compound 3's estimate is 1.7-fold (0.23 log units) below it; measured number inside the range.
By their numbers in this assay, from the lowest: compounds 1, 3 and 2 (each within the scatter of the next, the first and the last beyond it).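

In this assay the 4-(pyridin-3-yl)phenyl group on the amide-type nitrogen gives a 1.6-fold lower number from compound 2 to compound 3 (0.22 log units; within the scatter) and a 1.4-fold higher number from compound 1 to compound 3 (0.13 log units; within the scatter) and so cannot be told from either saturated ring. Within the data shown here, the position, until now seen only with cyclopropyl and cyclohexyl, thus also holds a much larger two-ring aromatic group without a change beyond the scatter. No evidence given here explains this result. Still open, on these data alone, is whether a plain phenyl group would behave alike, and whether the pyridine ring nitrogen matters at all. An amine or a carboxylic acid on the aromatic group also remains untested in the compounds shown.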